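A few compounds are considered here, and "the series" means these few. Any claim that something is new, unique, unknown or untested is made for them only; others in the source may bear on it.

Of the compounds shown here, three that share one core have been tested in a functional assay on A549 cells (Homo sapiens) for inhibition, with a stated time of 48 h, tested at 50 uM; on this read-out lower numbers stand for less inhibition of growth and higher numbers for more inhibition of growth at the one concentration tested. Here compound 1 `C=C[C@@](C)(/C=C/c1ccc(OC(C)=O)cc1)CCC=C(C)C` gives 72%, compound 2 `C=C[C@@](C)(/C=C/c1ccc(OC(=O)CCC)cc1)CCC=C(C)C` gives 50% and compound 3 `C=C[C@@](C)(/C=C/c1ccc(OC(=O)CCCCCCCCCCCCCCC)cc1)CCC=C(C)C` gives 61%. Compound 2 therefore stands lowest of the three, and both of the others lie beyond the scatter from it.

The next compound to be measured is compound 4 `C=C[C@@](C)(/C=C/c1ccc(OC)cc1)CCC=C(C)C`. Its difference from compound 2 is methyl in place of propylcarbonyl on an oxygen on an aromatic ring.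

Among the measured compounds shown here, two measured steps bear on this change, but only indirectly: a number 22 percentage points lower from compound 1 to compound 2 (beyond the scatter) and a number 11 percentage points higher from compound 2 to compound 3 (beyond the scatter). Both are modest, they run in opposite directions, and both alter the chain on the carbonyl. For the measured compounds named here, no measured compound lacks that carbonyl, so the data do not show what removing it does. The two steps serve only as a guide to how far the number can move in this small series.

Compound 2, at 50%, already sits at the low end, so a small rise seems slightly more likely than a fall. The estimated step is a number 6 percentage points higher from compound 2 to compound 4 (within the scatter), which would lie within the scatter, although a modest move either way remains possible. Compound 4 is expected to give 56%, with an estimated range from 36% to 76%.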

Compound 4, percent growth inhibition at one concentration: 12%
Compound 4: middle estimate off by 44 percentage points, on the high side; the measured number lies below the stated range.
By their numbers in this assay, from the lowest: compound 4; then compound 2; then compound 3; then compound 1.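

On an oxygen on an aromatic ring, replacing the ester group with methyl moves the number much further in this assay than any change of chain length on the carbonyl did: methyl in place of propylcarbonyl gives a number 38 percentage points lower from compound 2 to compound 4 (beyond the scatter), and methyl in place of acetyl gives a number 60 percentage points lower from compound 1 to compound 4 (beyond the scatter). Among the compounds shown here, the earlier steps showed only that the number shifts modestly as the chain on the carbonyl changes, whereas compound 4 at 12% now lies below all three compounds that keep a carbonyl on this oxygen, and none of the four goes against that order. Nothing in the data shown gives a reason for this drop.

The compounds shown do not separate the effect of losing the carbonyl from that of having a methyl on the oxygen, and a plain hydroxyl group or an ethyl or longer chain joined directly to this oxygen would help to tell these apart. Going by these compounds, it also remains open whether an amide in place of the ester would keep the higher numbers seen with compound 1 and compound 3.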